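This account rests on a few compounds, and the source may have more. Where it says the series, first, only, none or still open, it means among the compounds named here.

Measured so far:
compound 1 `CCNc1nc(Cl)nc(N[C@H](C)c2ccccc2)n1` — 2690 nM
compound 2 `CC[C@H](C)Nc1nc(Cl)nc(N[C@@H](C)c2ccccc2)n1` — 14100 nM

In an ADME assay on the whole organism for inhibition, with Echinochloa crus-galli var. formosensis as the target, with a stated time of 4 days (a lower number here means a stronger inhibitor, a higher number a weaker inhibitor), compound 1 gives the lowest of the two numbers; compound 2 sits a step beyond the scatter above it. Compound 3 `CCN(c1nc(Cl)nc(N[C@H](C)c2ccccc2)n1)C(C)C` is not yet measured. It differs from compound 1 in one place: isopropyl in place of hydrogen on a nitrogen on an aromatic ring. Among the compounds with values here, no measured pair shows this kind of change, so the size of the step is open. The expectation is a step in this assay toward a higher number, beyond the scatter, as a 5.6-fold higher number from compound 1 to compound 3 (0.75 log units; beyond the scatter). For compound 3 the estimate is 15000 nM, with a range from 4000 nM to 60000 nM.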

Compound 3, half-maximal inhibitory concentration: 52500 nM
The estimate for compound 3 lay 3.5-fold (0.54 log units) below the measured number; measured number inside the range.
By their numbers in this assay, from the lowest: compound 1; then compound 2; then compound 3.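

In this assay, isopropyl in place of hydrogen on a nitrogen on an aromatic ring gives a 20-fold higher number from compound 1 to compound 3 (1.29 log units; beyond the scatter) and turns ethylamino into ethyl(isopropyl)amino. Within the data shown here, this is the first single-place change, and it shows that this nitrogen is sensitive to substitution: the added isopropyl carries a large penalty in this whole-organism read-out. No available measurement bears on the reason for this step.

Still open, on these data alone, is whether a methyl on the same nitrogen would cost as much as isopropyl. Also open, as far as these compounds go, is whether a longer chain in place of the ethyl, with the hydrogen kept, would shift the number at all.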